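Second methoxy added to the aryl ring of compound 2

A few compounds are considered here, and "the series" means these few. Any claim that something is new, unique, unknown or untested is made for them only; others in the source may bear on it.

Working notes on the series. All members share one core bearing a phenyl ring that differs only in its methoxy substitution. Compound 2 `COc1cccc(-c2nc(Cc3c[nH]c4ccccc34)no2)c1` carries a single methoxy; in a functional assay on cells (Splenocyte, Mus musculus, strain BALB/c) for inhibition, read by scintillation counting and thymidine incorporation, with stated times of 48 h and 8 h (a lower number here means a stronger inhibitor, a higher number a weaker inhibitor), compound 2 gives 11100 nM. Compound 3 `COc1ccc(OC)c(-c2nc(Cc3c[nH]c4ccccc34)no2)c1` gives 8400 nM and compound 1 `COc1cc(-c2nc(Cc3c[nH]c4ccccc34)no2)cc(OC)c1OC` gives 3100 nM. Of the three numbers compound 2 shows the highest, yet it is separated beyond the scatter only from compound 1; the step from compound 2 to compound 3 is a 1.3-fold lower number from compound 2 to compound 3 (0.12 log units; within the scatter).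

Compound 4 `COc1cc(OC)cc(-c2nc(Cc3c[nH]c4ccccc34)no2)c1` has not been measured. It differs from compound 2 as follows: methoxy in place of hydrogen on an aromatic carbon. Among the compounds with values here, the one measured step of the same kind, methoxy in place of hydrogen on an aromatic carbon, is that from compound 2 to compound 3, and it stayed within the scatter. Within the data shown here, compound 1, which carries two more methoxy groups than compound 2, lies lower beyond the scatter, but no single step to it is available. The expectation for compound 4 is therefore a small lowering in this assay, at most at the edge of the scatter, the step from compound 2 to compound 4 being estimated as a 1.9-fold lower number from compound 2 to compound 4 (0.27 log units; within the scatter). Compound 4 is expected to give 6000 nM, with a range from 2500 nM to 14000 nM.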

Compound 4, half-maximal inhibitory concentration: 13900 nM
Compound 4: middle estimate off by 2.3-fold (0.36 log units), on the low side, and the stated range covers the measured number.
By their numbers in this assay, from the lowest: compound 1; then compounds 3, 2 and 4 (each within the scatter of the next).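

In this assay, methoxy in place of hydrogen at this position, on an aromatic carbon meta to a large group and meta to a methoxy group, gives a 1.3-fold higher number from compound 2 to compound 4 (0.10 log units; within the scatter), so this addition has no readable effect on its own. A clear gap appears only with the further methoxy, a 4.5-fold higher number from compound 1 to compound 4 (0.65 log units; beyond the scatter), where hydrogen stands in place of methoxy on an aromatic carbon. Methoxy in place of hydrogen therefore has no single size of effect in this series, and the outcome depends on the core that receives it: the same change on two cores in this assay, a 1.3-fold lower number (0.12 log units; within the scatter) from compound 2 to compound 3 and a 4.5-fold lower number (0.65 log units; beyond the scatter) from compound 4 to compound 1, 3.4-fold (0.53 log units) apart, beyond the scatter of two such steps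

Still open is whether the methoxy that sets the number of compound 1 apart would have the same effect without the other methoxy groups on that ring, since each compound shown carries it only in that one setting. The compounds shown also do not tell how a hydroxyl, an ethoxy or an amine would compare with methoxy at either of these places on the ring.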